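Changing the aryl group on a piperazine series tested on a T-type channel

A few compounds are considered here, and "the series" means these few. Any claim that something is new, unique, unknown or untested is made for them only; others in the source may bear on it.

Measured compounds:
- Compound 1, `CCCc1nc(-c2ccccc2)c(CNCCN2CCN(c3ccccc3F)CC2)o1`, gives 46.5%
- Compound 2, `CCCc1nc(-c2ccccc2)c(CNCCCN2CCN(c3cccc(F)c3)CC2)o1`, gives 68.9%
- Compound 3, `Cc1nc(-c2ccccc2)c(CNCCCN2CCN(c3ccc(Cl)cc3)CC2)o1`, gives 38.1%

All three were tested in an assay on HEK293 cells for inhibition of Voltage-dependent T-type calcium channel subunit alpha-1G (Homo sapiens), read by fluorescence, tested at 10 uM; a lower number here means less inhibition, a higher number more inhibition at the concentration tested (going by the name of the read-out). Compound 2 stands highest of the three numbers. Its nearest neighbour is compound 1, whose value is lower by a margin beyond the usual scatter, and the furthest is compound 3, lower still, also beyond the scatter. No pair among these three differs in only one place, so no single step can be isolated from them; they share a core and differ in several positions at once, including the length of the chain and the substituent on the aryl ring.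

Compound 4, `CCCc1nc(-c2ccccc2)c(CNCCCN2CCN(c3ccccc3C(F)(F)F)CC2)o1`, has not yet been measured in this assay. It differs from compound 2 in one place: 2-(trifluoromethyl)phenyl in place of 3-fluorophenyl on an amine nitrogen in a ring. Within the data shown here, since no measured pair isolates a change of the aryl substituent, the size of this step can only be guessed from how widely the three known values spread. A change of moderate size in either direction seems plausible, with a somewhat lower value expected on balance because compound 1, bearing a different aryl group, gives 46.5%. The step from compound 2 to compound 4 is thus estimated at a number 13.9 percentage points lower from compound 2 to compound 4 (beyond the scatter). Compound 4 is expected to give 55% in this assay, within a range from 30% to 80%.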

Compound 4, a percentage reported as inhibition, at one concentration (the size of the read-out at that concentration, not a potency): 45%
Compound 4: the middle estimate sits 10 percentage points above what was measured; measured number inside the range.
By their numbers in this assay, from the lowest: compounds 3, 4 and 1 (each within the scatter of the next); then compound 2.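

Among these compounds, replacing 3-fluorophenyl with 2-(trifluoromethyl)phenyl on an amine nitrogen in a ring gives, in this assay, a number 23.9 percentage points lower from compound 2 to compound 4 (beyond the scatter) and is the first change here confined to one place. The earlier compounds shown here differed in several places at once, so their spread could not be tied to any single part, whereas this pair shows that the aryl group at this position can, on its own, shift the read-out by more than the scatter. No measurement shown here accounts for the size or direction of this step.

The change also swaps two things together, since both the substituent and its place on the aryl ring differ between compound 2 and compound 4, so this one step cannot separate their contributions. From the compounds shown here alone, a 3-(trifluoromethyl)phenyl group on the same nitrogen, with the rest of compound 2 unchanged, would keep the place of the substituent and change only its identity, and how that group would read in this assay remains open.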